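Compound 2 to compound 4: the hydroxy exchange

The compounds below may be only part of what the source reports. "The series", "measured", "known", "first", "only" and "open" are said of these compounds alone.

compound 1 `CO[C@@H]1[C@H](OC(=O)N[C@@H](C(N)=O)C(C)(C)O)CC[C@]2(CO2)[C@H]1[C@@]1(C)O[C@@H]1C[C@@H]1OC1(C)C` gives 39 ng.h/mL
compound 2 `CO[C@@H]1[C@H](OC(=O)N[C@@H](C(N)=O)C(C)C)CC[C@]2(CO2)[C@H]1[C@@]1(C)O[C@@H]1C[C@H]1OC1(C)C` gives 123 ng.h/mL
compound 3 `CO[C@@H]1[C@H](OC(=O)N[C@@H](C(N)=O)C(C)C)CC[C@]2(CO2)[C@H]1[C@@]1(C)O[C@@H]1C[C@@H]1OC1(C)C` gives 83.3 ng.h/mL

In an ADME assay on the whole organism for pharmacokinetics, with Homo sapiens as the target, with a stated time of 21 days, at a dose of 15 mg by the oral route (on this read-out higher numbers stand for higher exposure at the dose given and lower numbers for lower exposure), compound 2 gives 123 ng.h/mL, within the scatter of compound 3 at 83.3 ng.h/mL, while compound 1 lies lower at 39 ng.h/mL, beyond the scatter.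

Compound 4 `CO[C@@H]1[C@H](OC(=O)N[C@@H](C(N)=O)C(C)(C)O)CC[C@]2(CO2)[C@H]1[C@@]1(C)O[C@@H]1C[C@H]1OC1(C)C` comes from compound 2 by hydroxy in place of hydrogen on a saturated chain carbon bound to three saturated chain carbons, which reads as isopropyl to 1-hydroxy-1-methylethyl. The same exchange has been measured once, in the opposite sense, as a 2.1-fold higher number from compound 1 to compound 3 (0.33 log units; beyond the scatter). The configuration step, a 1.5-fold lower number from compound 2 to compound 3 (0.17 log units; within the scatter), stays within the scatter, so that pair should carry over to the other configuration. In this assay a modest fall is therefore expected, resting on that single pair. The expected change is a 2.1-fold lower number from compound 2 to compound 4 (0.33 log units; beyond the scatter). For compound 4 the estimate is 58 ng.h/mL, with an expected range of 30 ng.h/mL to 110 ng.h/mL.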

Compound 4, area under the concentration-time curve: 44.4 ng.h/mL
Compound 4: middle estimate off by 1.3-fold (0.12 log units), on the high side; measured number inside the range.
By their numbers in this assay, from the lowest: compounds 1, 4, 3 and 2 (each within the scatter of the next, the first and the last beyond it).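

In this assay, the exchange of isopropyl to 1-hydroxy-1-methylethyl now reads on both configurations, with a 2.8-fold lower number from compound 2 to compound 4 (0.44 log units; beyond the scatter), so the fall no longer rests on a single pair, and the two readings agree: the same change on two cores in this assay, a 2.1-fold higher number (0.33 log units; beyond the scatter) from compound 1 to compound 3 and a 2.8-fold higher number (0.44 log units; beyond the scatter) from compound 4 to compound 2, 1.3-fold (0.11 log units) apart, within the scatter of two such steps. With 1-hydroxy-1-methylethyl in place, the configuration at the saturated ring carbon also stays within the scatter, at a 1.1-fold higher number from compound 1 to compound 4 (0.06 log units; within the scatter), as it does in the isopropyl pair with a 1.5-fold lower number from compound 2 to compound 3 (0.17 log units; within the scatter).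

The compounds shown hold only isopropyl and 1-hydroxy-1-methylethyl at this place. On these data alone, how an amine, a methoxy group or a carboxylic acid on that carbon would read in this assay stays open.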